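The compounds below may be only part of what the source reports. "The series", "measured", "known", "first", "only" and "open" are said of these compounds alone.

Measured so far:
compound 1, `CCN(CCC#N)c1nc(C)nc2c(-c3c(C)cc(OC)cc3OC)c(C)nn12`: 2.48 nM
compound 2, `COCC(COC)Nc1nc(C)nc2c(-c3ccc(OC)cc3C)c(C)nn12`: 9.7 nM
compound 3, `C=CCN(CC=C)c1nc(C)nc2c(-c3c(C)cc(OC)cc3OC)c(C)nn12`: 1 nM

All three share one core and were read in an assay on cell membranes for displacement of a labelled ligand from corticotropin-releasing factor receptor 1 (Rattus norvegicus); on this read-out lower numbers stand for stronger inhibition and higher numbers for weaker inhibition. Compound 2 carries the highest number of the three; compound 1 and compound 3 sit lower, compound 3 lowest of all. Within the data shown here, compound 1 and compound 3 carry a different aryl group from compound 2, so their comparison with compound 2 mixes two changes and no single step is drawn from it.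

Compound 4, `CCCN(CC1CC1)c1nc(C)nc2c(-c3ccc(OC)cc3C)c(C)nn12`, is not yet measured. It differs from compound 2 by (cyclopropylmethyl)(propyl)amino in place of (2-methoxy-1-(methoxymethyl)ethyl)amino on an aromatic carbon. Among the measured compounds shown here, the one measured step at the same position, a 2.5-fold lower number from compound 1 to compound 3 (0.39 log units; beyond the scatter), exchanged one group without a hydrogen-bond donor for another and gave a modest gain. The change from compound 2 to compound 4 also replaces a group bearing a hydrogen-bond donor with one bearing none, so a step of similar or somewhat larger size in the same direction in this assay is expected. Compound 4 is therefore expected to give about 3.5 nM (range 1.2 nM to 10 nM). This expected step, a 2.8-fold lower number from compound 2 to compound 4 (0.44 log units; beyond the scatter), rests on a single analogous measurement made on a different aryl group and is uncertain.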

Compound 4, half-maximal inhibitory concentration: 1.96 nM
Compound 4: the middle estimate sits 1.8-fold (0.25 log units) above what was measured; measured number inside the range.
By their numbers in this assay, from the lowest: compounds 3, 4 and 1 (each within the scatter of the next, the first and the last beyond it); then compound 2.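

In this assay, the change at the carbon opposite the ring nitrogen now has a measured step on the aryl group of compound 2: a 4.9-fold lower number from compound 2 to compound 4 (0.69 log units; beyond the scatter). Unlike a 2.5-fold lower number from compound 1 to compound 3 (0.39 log units; beyond the scatter), where neither group has a hydrogen-bond donor, this step removes the donor and both ether oxygens and adds a three-membered carbon ring, while the heavy-atom count stays the same. The number therefore falls beyond the scatter with no change in that count, but nothing measured here explains the fall.

Open, on these data alone, is which part of the exchange goes with the step: bis(2-methoxyethyl)amino would separate the amino hydrogen from the ether oxygens, and dipropylamino would isolate the cyclopropyl ring. Also open, as far as these compounds go, is whether (cyclopropylmethyl)(propyl)amino gives a similar number on the aryl group shared by compound 1 and compound 3.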